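A Shorter Tether to Naphthalen-1-yl in Compound 3

This account rests on a few compounds, and the source may have more. Where it says the series, first, only, none or still open, it means among the compounds named here.

Within the data shown here, compound 2 `Cc1ccccc1-c1cn(CCOc2cccc3ccccc23)c2cccc(-c3ccccc3C(=O)O)c12` holds the only number in this set: in an assay on isolated protein for binding affinity to Bcl2-associated agonist of cell death (Homo sapiens), read by fluorescence polarization (on this read-out higher numbers stand for weaker inhibition and lower numbers for stronger inhibition), compound 2 gives 250 nM. Compound 1 `CO[C@H]1/C=C/C[C@H](C)[C@@H](C)S(=O)(=O)CNc2ccc3c(c2)N(CC[C@@]2(CCCc4cc(Cl)ccc42)CO3)C[C@@H]2CC[C@H]21` has no result in this assay: for compound 1 the entry reads "not determined" (no result reported). Compound 3 `Cc1ccccc1-c1cn(Cc2cccc3ccccc23)c2cccc(-c3ccccc3C(=O)O)c12` differs from compound 2 in one place, (naphthalen-1-yl in place of ((naphthalen-1-yl)oxy)methyl on a saturated chain carbon bound to an aromatic nitrogen), so the naphthalen-1-yl group sits directly on the chain carbon. Among the measured compounds shown here, no step between measured compounds is available to calibrate this change, so only a rough expectation is possible: a moderate weakening that may or may not exceed the scatter. Compound 3 is therefore estimated at 600 nM, within 150 nM to 2500 nM, an expected step of a 2.4-fold higher number from compound 2 to compound 3 (0.38 log units; beyond the scatter).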

Compound 3, inhibition constant: 660 nM
Beside the measured number, compound 3's estimate is 1.1-fold (0.04 log units) below it, and the stated range covers the measured number.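

In this assay, among these compounds, naphthalen-1-yl in place of ((naphthalen-1-yl)oxy)methyl on a saturated chain carbon bound to an aromatic nitrogen gives a 2.6-fold higher number from compound 2 to compound 3 (0.42 log units; beyond the scatter) as the first measured step at this position. The change thus moves the number beyond the scatter, and binding remains measurable with the naphthalen-1-yl group directly on the chain carbon. Nothing shown here explains this step. The step removes the oxygen and shortens the tether together, so their separate contributions remain unresolved. Also open, as far as these compounds go, is how an amine linker or a longer chain carrying the naphthalen-1-yl group would read out here.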